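Isomeric acrylamide variant at the amide of compound 1

This account rests on a few compounds, and the source may have more. Where it says the series, first, only, none or still open, it means among the compounds named here.

Measured so far:
compound 1 `C=C(C)C(=O)NCCOc1ccc(Oc2c(-c3ccc(F)cc3)sc3cc(O)ccc23)cc1` — > 25000 nM
compound 2 `O=C(/C=C/CNCCOc1ccc(Oc2c(-c3ccc(F)cc3)sc3cc(O)ccc23)cc1)N1CCCCC1` — 8430 nM
compound 3 `O=C(/C=C/CNCCOc1ccc(Oc2c(-c3ccc(F)cc3)sc3cc(O)ccc23)cc1)N1CCCC1` — 11300 nM

In a functional assay on Ishikawa cells (Homo sapiens) for antiproliferative activity, read by CCK-8 assay, with a stated time of 48 h (on this read-out higher numbers stand for weaker inhibition and lower numbers for stronger inhibition), compound 1 reaches only the assay limit, > 25000 nM, so no number is known for it (the limit of > 25000 nM in this assay, at which 1 of the 3 values shown sits). Compound 2 and compound 3 differ from compound 1 at the amine nitrogen: an at least 2.9-fold lower number from compound 1 to compound 2 (0.47 log units; beyond the scatter) and an at least 2.2-fold lower number from compound 1 to compound 3 (0.34 log units; beyond the scatter), while between them a 1.3-fold higher number from compound 2 to compound 3 (0.13 log units; within the scatter).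

Compound 4 `C/C=C/C(=O)NCCOc1ccc(Oc2c(-c3ccc(F)cc3)sc3cc(O)ccc23)cc1` keeps the amide of compound 1 and changes it as follows: prop-1-en-1-yl in place of 1-methylethenyl on a carbonyl carbon. Among the compounds with values here, none of the measured steps touches this part of the structure, so no measured step bears on it directly. With compound 1 itself at a limit, compound 4 is expected to stay near that limit, giving an estimate of 30000 nM (range 10000 nM to 100000 nM). The implied step is expected to be a step that the limit leaves unreadable from compound 1 to compound 4, no change beyond the scatter.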

Compound 4, half-maximal inhibitory concentration: 12400 nM
The estimate for compound 4 lay 2.4-fold (0.38 log units) above the measured number; the range from low to high includes it.
By their numbers in this assay, from the lowest: compounds 2, 3 and 4 (each within the scatter of the next). At a limit, above all of these: compound 1.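

With prop-1-en-1-yl in place of 1-methylethenyl on the carbonyl carbon, the simple amide gains a measured number, with an at least 2.0-fold lower number from compound 1 to compound 4 (0.30 log units; that floor lies within the scatter). Compound 4 shows no separation from the longer side chains, with a 1.1-fold higher number from compound 3 to compound 4 (0.04 log units; within the scatter) and a 1.5-fold higher number from compound 2 to compound 4 (0.17 log units; within the scatter), so the piperidin-1-yl and pyrrolidin-1-yl carbonyl groups are not required for a measurable number. Compound 1 holds only a limit, so the true size of its step stays unread: the limit of > 25000 nM in this assay, at which 1 of the 4 values shown sits.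

Open, on these data alone, is whether a dimethylamino group or a carboxylic acid in place of prop-1-en-1-yl on the carbonyl carbon would move the number beyond the scatter around compound 4.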